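Amide variation on a pyrazole carboxamide series with three limits

This account rests on a few compounds, and the source may have more. Where it says the series, first, only, none or still open, it means among the compounds named here.

Working notes on the amide position of the shared core. Compound 3 `COc1cccc(-c2cn(-c3ccc(C(F)(F)F)cc3)nc2C(=O)N2CCc3ccccc3C2)c1` carries a 1,2,3,4-tetrahydroisoquinolin-2-yl group on the carbonyl carbon. In a functional assay on BMDM cells (Mus musculus, strain C57BL/6) for inhibition, with a stated time of 2 days (on this read-out lower numbers stand for stronger inhibition and higher numbers for weaker inhibition), compound 3 gives only a limit, > 30000 nM. Compound 1 `COc1cccc(-c2cn(-c3ccc(C(F)(F)F)cc3)nc2C(=O)N2CCN(c3ncccn3)CC2)c1` differs from compound 3 in the same place. In this assay compound 1 likewise gives only a limit, > 30000 nM. Compound 2 `N#Cc1ccc(-c2cn(CC(=O)Nc3nc4ccccc4s3)nn2)cc1` belongs to a different scaffold. In this assay compound 2 also reaches only a limit, > 30000 nM. Within the data shown here, the one step that can be traced, a step that the two limits leave unreadable from compound 1 to compound 3, is therefore of unknown size, since both ends are limits. Among the measured compounds shown here, this is summed up by the limit of > 30000 nM in this assay, at which 3 of the 3 values shown sit, and nothing so far places any compound at a readable number.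

Compound 4 `COc1cccc(-c2cn(-c3ccc(C(F)(F)F)cc3)nc2C(=O)NCCCN(C)C)c1` is the next change at the same carbonyl carbon: (3-(dimethylamino)propyl)amino in place of 1,2,3,4-tetrahydroisoquinolin-2-yl on a carbonyl carbon. For the measured compounds named here, no measured step bears on this change with a readable size, so no direction can be drawn from the numbers; the only guidance is that every measured amide so far sits at the limit. For compound 4 a value near the same limit is expected, estimated at 30000 nM with a range from 8000 nM to 100000 nM. The step of a number no higher from compound 3 to compound 4 (the limit leaves the size open) is thus expected to be none beyond the scatter, with a high chance that only a limit is again reported.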

Compound 4, half-maximal inhibitory concentration: > 30000 nM
Compound 4 ended at the assay's limit; the forecaster's own chance of this, stated with the estimate: 75%; the middle value lies on the limit itself.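

Compound 4 gives only a limit, as do compound 1 and compound 3, so the steps from compound 1 and compound 3 to compound 4 cannot be read. The compounds shown leave open whether any amide at this carbonyl carbon of the shared core gives a readable number in this assay, and the series still rests on a single mark: the limit of > 30000 nM in this assay, at which 4 of the 4 values shown sit.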